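The compounds below may be only part of what the source reports. "The series", "measured", "known", "first", "only" and "open" are said of these compounds alone.

Compound 1 `CCS(=O)(=O)Nc1cc(C2CCCCC2)cc2c1CCCC2c1c[nH]cn1`: in an assay on isolated protein (Cricetulus griseus) for binding affinity to Alpha-1B adrenergic receptor (Mesocricetus auratus), read by radioligand binding (on this read-out higher numbers stand for weaker inhibition and lower numbers for stronger inhibition), compound 1 gives 891 nM.
Compound 2 `CCS(=O)(=O)Nc1cccc2c1CCCC2c1c[nH]cn1`: in this assay compound 2 gives 1320 nM.
Compound 3 `CCS(=O)(=O)Nc1cccc2c1CCCC2c1c[nH]c(C)n1`: in this assay compound 3 reaches only the assay limit, < 10000 nM, so no number is known for it.

Compound 2 stands at the highest of the two numbers in this assay; its nearest neighbour, compound 1, differs by a 1.5-fold higher number from compound 1 to compound 2 (0.17 log units; within the scatter), a gap within the scatter. The third value is a limit, (the limit of < 10000 nM in this assay, at which 1 of the 3 values shown sits), and carries no number.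

Compound 4 `CC(C)S(=O)(=O)Nc1cccc2c1CCCC2c1c[nH]cn1` differs from compound 2 by methyl in place of hydrogen on a saturated chain carbon bound to a saturated chain carbon and a sulfonyl sulfur. Neither measured step touches the sulfonyl chain: the step of a 1.5-fold higher number from compound 1 to compound 2 (0.17 log units; within the scatter) concerns a ring substituent and stays within the scatter, and the step that the limit leaves unreadable from compound 2 to compound 3 cannot be sized because of the limit (the limit of < 10000 nM in this assay, at which 1 of the 3 values shown sits). Nothing measured here therefore points to a change beyond the scatter in this assay in either direction, and compound 4 is expected to sit near compound 2, with a step of a 1.0-fold lower number from compound 2 to compound 4 (0.01 log units; within the scatter) estimated. Compound 4 is estimated at 1300 nM, between 450 nM and 3800 nM.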

Compound 4, inhibition constant: < 10000 nM
Compound 4: a limit, no number (the forecaster's own chance of this, stated with the estimate: 15%); the middle value lies beyond the limit too.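

Compound 4 reaches only a limit in this assay, < 10000 nM, so no new step can be read from compound 2 to compound 4. The compounds shown leave open how large the difference between ethylsulfonyl and isopropylsulfonyl is in this assay.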